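The compounds below may be only part of what the source reports. "The series", "measured", "known", "first", "only" and "open" are said of these compounds alone.

Measured so far in a physicochemical assay for solubility, read by LC-MS, in phosphate buffer, with a stated time of 24 h, at pH 7.4 (a higher number here means a more soluble compound, a lower number a less soluble compound), are these compounds:
- compound 1 `CC(=O)N1CCC(c2cnc(NCc3c(F)ccc4c3CCO4)c3cn[nH]c(=O)c23)CC1` gives < 2000 nM as a limit
- compound 2 `CNC(=O)c1cc(-c2cnc(NCc3c(F)ccc4c3CCO4)c3cn[nH]c(=O)c23)n(C)n1` gives 7000 nM as a number

For the measured compounds named here, compound 2 holds the only actual number so far. Going by the values given here, the single measured step is an at least 3.5-fold higher number from compound 1 to compound 2 (0.54 log units; beyond the scatter) and it replaced 1-acetylpiperidin-4-yl, a group without an aromatic ring, so it offers only a loose guide here. Compound 3 `CNC(=O)c1ccc(-c2cnc(NCc3c(F)ccc4c3CCO4)c3cn[nH]c(=O)c23)c(C)n1` changes the same place on an aromatic carbon: 2-methyl-6-(methylcarbamoyl)pyridin-3-yl in place of 1-methyl-3-(methylcarbamoyl)-1H-pyrazol-5-yl on an aromatic carbon and the methylcarbamoyl group stays. No step beyond the scatter is expected, the estimated step being a 1.4-fold lower number from compound 2 to compound 3 (0.15 log units; within the scatter) in this assay as a working figure. Compound 3 is expected at 5000 nM with an estimated range from 1800 nM to 14000 nM for now.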

Compound 3, solubility: 19000 nM
The estimate for compound 3 lay 3.8-fold (0.58 log units) below the measured number, outside the stated range (above it).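

In this assay, with the methylcarbamoyl group kept, 2-methyl-6-(methylcarbamoyl)pyridin-3-yl in place of 1-methyl-3-(methylcarbamoyl)-1H-pyrazol-5-yl gives a 2.7-fold higher number from compound 2 to compound 3 (0.43 log units; beyond the scatter), so the read-out at this position depends on more than that group. Replacing 1-acetylpiperidin-4-yl with the same pyridinyl group gives an at least 9.5-fold higher number from compound 1 to compound 3 (0.97 log units; beyond the scatter). This step rests on a limit for compound 1, not a number: the limit of < 2000 nM in this assay, at which 1 of the 3 values shown sits.

Going by these compounds, whether the step from the pyrazolyl to the pyridinyl group follows the ring or its methyl group stays open. Also open, on these data alone, is how an amine or a carboxylic acid in place of the methylcarbamoyl group would read in this assay.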